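The source may hold more compounds than are shown below. What is called first, only, known or untested is meant among the compounds shown, and "the series" means these compounds.

In a functional assay on LNCaP cells (Homo sapiens) for antiproliferative activity, read by propidium iodide staining, with a stated time of 96 h (on this read-out lower numbers stand for stronger inhibition and higher numbers for weaker inhibition), compound 1 `CC(O)(COc1ccc(C#N)cc1C(F)(F)F)C(=O)Nc1ccc(S(F)(F)(F)(F)F)cc1` gives 100000 nM, compound 2 `CC(O)(CS(=O)(=O)c1ccc(S(F)(F)(F)(F)F)cc1)C(=O)Nc1ccc(S(F)(F)(F)(F)F)cc1` gives 29200 nM and compound 3 `CC(O)(CS(=O)(=O)c1ccc(F)cc1)C(=O)Nc1ccc(S(F)(F)(F)(F)F)cc1` gives 18200 nM. Compound 3 thus stands level with compound 2, and its number is well under that of compound 1. The next structure, compound 4 `CC(O)(CS(=O)(=O)c1cccc(C(F)(F)F)c1)C(=O)Nc1ccc(S(F)(F)(F)(F)F)cc1`, carries 3-(trifluoromethyl)phenyl in place of 4-fluorophenyl on a sulfonyl sulfur. Among the compounds with values here, only one measured step changes this aromatic ring: a 1.6-fold lower number from compound 2 to compound 3 (0.21 log units; within the scatter). Within the data shown here, no measured compound has a trifluoromethyl group there, so this is weak guidance, and no shift beyond the scatter is expected in this assay. The expected size is an estimated 1.1-fold lower number from compound 3 to compound 4 (0.06 log units; within the scatter). Compound 4 is estimated at 16000 nM, with an expected range from 6000 nM to 42000 nM.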

Compound 4, half-maximal inhibitory concentration: 21000 nM
Estimate against measurement, compound 4: 1.3-fold (0.12 log units) below; the range from low to high includes it.
By their numbers in this assay, from the lowest: compounds 3, 4 and 2 (each within the scatter of the next); then compound 1.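

Replacing 4-fluorophenyl with 3-(trifluoromethyl)phenyl on the sulfonyl sulfur gives a 1.2-fold higher number from compound 3 to compound 4 (0.06 log units; within the scatter) in this assay. This is a second swap at this place that stays within the scatter, now with a group of 10 heavy atoms in place of 7, so both ring changes seen so far leave the number unresolved. Nothing measured here speaks to why this place responds so little. Still open, going by these compounds, is whether a ring carrying an amine or a carboxylic acid would give a step beyond the scatter. Also open, on these data alone, is whether replacing the ring with a longer chain would do so.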